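Swapping a Sulfanyl Group for a Sulfonyl on Two Cores

The source may report more compounds than this note shows. Statements on the series, on what has been measured and on what is new or still open speak of the compounds shown alone.

Compound 1 `CCN(CC)CCNC(=O)c1ccc(C(CC)(CC)c2ccc(OCSc3ccccc3)c(C)c2)n1CC` carries a phenylsulfanyl group on a saturated chain carbon bound to an oxygen on an aromatic ring. In a functional assay on MCF7 cells (Homo sapiens) for antiproliferative activity, read by MTT assay, with a stated time of 24 h (a lower number here means a stronger inhibitor, a higher number a weaker inhibitor), compound 1 gives 4900 nM. Compound 2 `CCN(CC)CCNC(=O)c1ccc(C(CC)(CC)c2ccc(OCS(C)(=O)=O)c(C)c2)n1CC` differs from it only by the change (methylsulfonyl in place of phenylsulfanyl on a saturated chain carbon bound to an oxygen on an aromatic ring). In this assay compound 2 gives 14700 nM, so that a 3.0-fold higher number from compound 1 to compound 2 (0.48 log units; beyond the scatter). Compound 3 `CCN(CC)CCNC(=O)c1cc(C(CC)(CC)c2ccc(OCSc3ccccc3)c(C)c2)cn1CC` has the same atoms as compound 1, joined differently; the difference between the two cores is not broken down here. In this assay compound 3 gives 4700 nM, a value within the scatter of that of compound 1. Compound 4 `CCN(CC)CCNC(=O)c1cc(C(CC)(CC)c2ccc(OCS(C)(=O)=O)c(C)c2)cn1CC` has not yet been measured. It differs from compound 3 by methylsulfonyl in place of phenylsulfanyl on a saturated chain carbon bound to an oxygen on an aromatic ring, the same kind of change that separates compound 2 from compound 1, at a place described in the same words on both cores. Given that the earlier step read a 3.0-fold higher number from compound 1 to compound 2 (0.48 log units; beyond the scatter) and that compound 3 starts from 4700 nM, a step of the same size is expected here, a 3.0-fold higher number from compound 3 to compound 4 (0.47 log units; beyond the scatter). Compound 4 is therefore estimated to give 14000 nM in this assay, most likely somewhere between 7000 nM and 30000 nM.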

Compound 4, half-maximal inhibitory concentration: 16300 nM
Beside the measured number, compound 4's estimate is 1.2-fold (0.07 log units) below it; the range from low to high includes it.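

The second core shows a 3.5-fold higher number from compound 3 to compound 4 (0.54 log units; beyond the scatter) in this assay when methylsulfonyl replaces phenylsulfanyl, so the change gives a weaker inhibitor here, as it does on the core of compound 1. Set side by side, the two steps agree, and on these two cores the change carries over at much the same size: the same change on two cores in this assay, a 3.0-fold higher number (0.48 log units; beyond the scatter) from compound 1 to compound 2 and a 3.5-fold higher number (0.54 log units; beyond the scatter) from compound 3 to compound 4, 1.2-fold (0.06 log units) apart, within the scatter of two such steps. Going by these compounds alone, this is still only one change on two cores in a single assay, so it does not show that the step would hold on any other core, and with the aromatic ring leaving and two double bonds entering in the same swap, these compounds cannot tell which part of the change matters.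

The compounds shown leave open what a phenylsulfonyl or a methylsulfanyl group would do at this place, and either could help separate the loss of the ring from the change at the sulfur. Also open, as far as these compounds go, is whether a group without sulfur, such as a carboxylic acid or an amine, would behave alike on both cores.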